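Replacing Cyclopropyl with Isopentyl: Expected Solubility of Compound 3

The source may hold more compounds than are shown below. What is called first, only, known or untested is meant among the compounds shown, and "the series" means these compounds.

Measured compounds:
Compound 1, `CC(=O)NC[C@H]1CN(c2ccc(OC[C@@H](O)CNC3CC3)c(F)c2)C(=O)O1`: 96000000 nM
Compound 2, `CC(=O)NC[C@H]1CN(c2ccc(OC[C@H](O)CNC3CC3)c(F)c2)C(=O)O1`: 2200000 nM

Among the measured compounds shown here, in a physicochemical assay for solubility, read by HPLC (a higher number here means a more soluble compound, a lower number a less soluble compound), compound 2 gives the lowest of the two numbers measured, the only comparison being the step of a 44-fold lower number from compound 1 to compound 2 (1.64 log units; beyond the scatter), which rests on (the fact that compounds 1 and 2 differ only in the configuration as drawn). Compound 3, `CC(=O)NC[C@H]1CN(c2ccc(OC[C@H](O)CNCCC(C)C)c(F)c2)C(=O)O1`, differs from compound 2 by isopentyl in place of cyclopropyl on an amine nitrogen. For the measured compounds named here, the one measured step concerns configuration alone, not an exchange of alkyl groups, so it offers no direct guide for this change. Compound 3 is therefore expected to give 1100000 nM, within 300000 nM to 4000000 nM. The expected step of a 2.0-fold lower number from compound 2 to compound 3 (0.30 log units; within the scatter) is estimated to be small.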

Compound 3, solubility: 7280000 nM
Beside the measured number, compound 3's estimate is 6.6-fold (0.82 log units) below it, and the stated range ends below it.
By their numbers in this assay, from the lowest: compound 2; then compound 3; then compound 1.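

In this assay, isopentyl in place of cyclopropyl on the amine nitrogen gives a 3.3-fold higher number from compound 2 to compound 3 (0.52 log units; beyond the scatter) and so shows that, with this configuration, an open chain here need not lower the number. The step of a 13-fold lower number from compound 1 to compound 3 (1.12 log units; beyond the scatter) combines this exchange with the change in configuration, and the exchange recovers only part of the drop seen with configuration alone. Nothing available explains why the number moves with this exchange.

Going by these compounds, whether isopentyl would have the same effect in the configuration of compound 1 remains open. So does the effect of a longer chain or a carboxylic acid on this amine nitrogen.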